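This account rests on a few compounds, and the source may have more. Where it says the series, first, only, none or still open, it means among the compounds named here.

Compound 1 `ClCc1ccc(Cn2cnc3c(Cl)ncnc32)cc1`: in a functional assay on NCI-H522 cells (Homo sapiens) for cytotoxicity, read by sulforhodamine B assay, with a stated time of 48 h (on this read-out higher numbers stand for lower toxicity in this test and lower numbers for higher toxicity in this test), compound 1 gives only a limit, > 100000 nM.
Compound 2 `ClCc1ccccc1Cn1cnc2c(Cl)nc(Cl)nc21`: in this assay compound 2 gives 6760 nM.
Compound 3 `ClCc1cccc(Cn2cnc3c(Cl)ncnc32)c1`: in this assay compound 3 gives only a limit, > 100000 nM.

Compound 3 stands at the limit of > 100000 nM in this assay, at which 2 of the 3 values shown sit; no number is known for it, and the same holds for compound 1. Compound 2 is the only one of the three with a measured number, and it is the one whose core carries a second chloro group. Compound 4 `ClCc1cccc(Cn2cnc3c(Cl)nc(Cl)nc32)c1` has not yet been tested in this assay. It differs from compound 3 in one place: chloro in place of hydrogen on an aromatic carbon, on the core shared by all four compounds. Going by the values given here, no step between two measured compounds is available to size this change. Among the compounds with values here, what the numbers show is that both compounds with a single chloro group on the core sit at the limit, while the one compound carrying the second chloro group returns a value; that observation rests on compound 2 alone. For compound 4 a move in this assay from the limit to a measurable value is expected, roughly the step of an at least 6.6-fold lower number from compound 3 to compound 4 (0.82 log units; beyond the scatter). Compound 4 is estimated at 15000 nM, with a range from 4000 nM to 60000 nM, and a fair chance that only a limit is returned again.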

Compound 4, concentration lethal to 50% of the cells: 17000 nM
Compound 4: the middle estimate sits 1.1-fold (0.05 log units) below what was measured; the measured number falls inside the stated range.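

In this assay, chloro in place of hydrogen on an aromatic carbon, between two ring nitrogen atoms, now has a measured effect within a single pair of compounds (an at least 5.8-fold lower number from compound 3 to compound 4 (0.76 log units; beyond the scatter)). Lower numbers here stand for higher toxicity in this test, so this one change is enough to bring the series off the limit without any change to the chloromethyl group. On these data alone, compound 3 gives only a limit, so the true size of the step stays unknown and only its lower bound can be read: the limit of > 100000 nM in this assay, at which 2 of the 4 values shown sit.

The compounds shown leave open whether this effect belongs to chloro itself or would also appear with an amine or a methoxy group at this place. They also leave open whether it would hold with a methyl group in place of the chloromethyl group that all four compounds carry.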